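This account rests on a few compounds, and the source may have more. Where it says the series, first, only, none or still open, it means among the compounds named here.

Going by the values given here, the three measured members share one core carrying three hydroxyphenyl groups. Compound 1 `Oc1ccc(-c2cc(-c3ccc(O)cc3)nc(-c3ccc(O)cc3)c2)cc1` bears three 4-hydroxyphenyl groups, and in a functional assay on DU-145 cells (Homo sapiens) for cytotoxicity, read by CCK-8 assay, with a stated time of 4 days (on this read-out higher numbers stand for weaker inhibition and lower numbers for stronger inhibition), compound 1 gives 3160 nM, the highest of the three numbers seen so far. Compound 2 `Oc1ccc(-c2cc(-c3cccc(O)c3)cc(-c3ccc(O)cc3)n2)cc1` gives 1400 nM and compound 3 `Oc1ccc(-c2cc(-c3ccccc3O)cc(-c3ccc(O)cc3)n2)cc1` gives 980 nM. The steps are a 2.3-fold lower number from compound 1 to compound 2 (0.35 log units; beyond the scatter) and a 3.2-fold lower number from compound 1 to compound 3 (0.51 log units; beyond the scatter), both beyond the scatter, whereas a 1.4-fold lower number from compound 2 to compound 3 (0.15 log units; within the scatter) stays within it.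

Compound 4 `Oc1ccc(-c2cc(-c3ccc(O)cc3)nc(-c3cccc(O)c3)c2)cc1` is not yet measured. Against compound 1 the change is 3-hydroxyphenyl in place of 4-hydroxyphenyl on an aromatic carbon. The same swap of a 4-hydroxyphenyl for a 3-hydroxyphenyl, carried out on a different aromatic carbon of the core, underlies a 2.3-fold lower number from compound 1 to compound 2 (0.35 log units; beyond the scatter); the step of a 3.2-fold lower number from compound 1 to compound 3 (0.51 log units; beyond the scatter) concerns a 2-hydroxyphenyl and bears only indirectly. Among the compounds with values here, no measured step reports this swap at the carbon next to the ring nitrogen, so the expectation rests on the single directly comparable step. A modest lowering of the number in this assay is therefore expected, about the size of that earlier step, and the expected step is a 2.0-fold lower number from compound 1 to compound 4 (0.30 log units; within the scatter). For compound 4 the estimate in this assay is 1600 nM, with a range from 800 nM to 3200 nM.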

Compound 4, half-maximal inhibitory concentration: 5800 nM
For compound 4 the middle estimate is 3.6-fold (0.56 log units) below the measured one, outside the stated range (above it).
By their numbers in this assay, from the lowest: compounds 3 and 2 (each within the scatter of the next); then compounds 1 and 4 (each within the scatter of the next).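

Moving the hydroxyl on the aryl group next to the ring nitrogen, with 3-hydroxyphenyl in place of 4-hydroxyphenyl, gives a 1.8-fold higher number from compound 1 to compound 4 (0.26 log units; within the scatter) in this assay, so this position shows no readable change from this swap. The same swap on a different aromatic carbon of the core gives a 2.3-fold lower number from compound 1 to compound 2 (0.35 log units; beyond the scatter) in this assay, which lies beyond the scatter, so the outcome of this change depends on the carbon that carries it, and the step seen at that other carbon does not transfer to the carbon next to the ring nitrogen. No measured information on these compounds accounts for this difference between the two carbons.

The compounds shown leave open how a 2-hydroxyphenyl would read on the carbon next to the ring nitrogen, and whether a methoxy group, an amine or a carboxylic acid in place of the hydroxyl would shift the number at either carbon. They also leave open whether the dependence on position holds beyond this single cell line and read-out, since each swap at each carbon rests on one pair of compounds.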